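The source may hold more compounds than are shown below. What is called first, only, known or untested is meant among the compounds shown, and "the series" means these compounds.

Measured so far:
compound 1 `COC(=O)c1ccccc1C(=O)OCCC[Se]C(F)(F)F`: 11300 nM
compound 2 `COc1ccc2c(c1)c(CC(=O)OCCC[Se]C(F)(F)F)c(C)n2C(=O)c1ccc(Cl)cc1`: 10500 nM
compound 3 `CC1=C(CC(=O)OCCC[Se]C(F)(F)F)c2cc(F)ccc2/C1=C\c1ccc([S+](C)[O-])cc1`: 16400 nM

In a functional assay on Caco-2 cells (Homo sapiens) for cytotoxicity, read by MTT assay, with a stated time of 72 h (a higher number here means a weaker inhibitor, a lower number a stronger inhibitor), compound 2 gives the lowest of these three numbers, yet its gaps to compound 1 and to compound 3 both lie within the scatter, so no order among the three can be read from them. Compound 4 `COc1ccc2c(c1)c(CC(=O)OCCC[Se]C#N)c(C)n2C(=O)c1ccc(Cl)cc1` differs from compound 2 in one place: cyano in place of trifluoromethyl on a selenium. All three measured compounds carry the same trifluoromethyl on a selenium and differ widely elsewhere, yet their numbers sit close together; nothing measured shows what this swap does. The step in this assay is therefore expected to be small, in either direction, and probably not beyond the scatter. For compound 4 in this assay the expected value is 10000 nM, with a range from 4000 nM to 25000 nM, meaning an expected step of a 1.1-fold lower number from compound 2 to compound 4 (0.02 log units; within the scatter).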

Compound 4, half-maximal inhibitory concentration: 32400 nM
Estimate against measurement, compound 4: 3.2-fold (0.51 log units) below, outside the stated range (above it).
By their numbers in this assay, from the lowest: compounds 2, 1, 3 and 4 (each within the scatter of the next, the first and the last beyond it).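

In this assay, the group on the selenium turns out to matter: cyano in place of trifluoromethyl gives a 3.1-fold higher number from compound 2 to compound 4 (0.49 log units; beyond the scatter), with the rest of the molecule unchanged. The earlier compounds shown here all carried trifluoromethyl on a selenium, so their closely grouped numbers could not reveal this. Nothing available here accounts for the step. From the compounds shown here alone, it remains open whether the same swap would shift compound 1 or compound 3 by a similar amount. Going by these compounds, how a methyl or a phenyl on the selenium would compare also remains open.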